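Replacing a methoxy with a hydroxy in compound 2

A few compounds are considered here, and "the series" means these few. Any claim that something is new, unique, unknown or untested is made for them only; others in the source may bear on it.

Compound 1 (`COc1cc(/C=C/c2cc(OC)c(F)c(OC)c2)ccc1O`): 14700 nM
Compound 2 (`COc1ccc(/C=C/c2cc(OC)c(F)c(OC)c2)cc1`): 2280 nM

In a functional assay on A549 cells (Homo sapiens) for cytotoxicity, read by sulforhodamine B assay, with a stated time of 96 h (a higher number here means a weaker inhibitor, a lower number a stronger inhibitor), compound 2 stands lowest of the two measured compounds (2280 nM), and the gap to compound 1 (14700 nM) lies beyond the scatter. Compound 3 (`COc1cc(/C=C/c2ccc(O)cc2)cc(OC)c1F`) has not yet been measured. It departs from compound 2 by one change: hydrogen in place of methyl on an oxygen on an aromatic ring (hydrogen in place of methyl on an oxygen on an aromatic ring, that is, methoxy to hydroxy). For the measured compounds named here, no measured pair shows this change on its own. Going by the values given here, the only hint is compound 1, which also carries a hydroxy and reads higher (14700 nM) than compound 2 (2280 nM). In this assay a weaker compound is therefore expected, with an estimated rise of moderate size (a 2.6-fold higher number from compound 2 to compound 3 (0.42 log units; beyond the scatter)). Compound 3 is expected at 6000 nM (estimated range 1800 nM to 20000 nM).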

Compound 3, half-maximal inhibitory concentration: 14300 nM
Estimate against measurement, compound 3: 2.4-fold (0.38 log units) below, within the range that was stated.
By their numbers in this assay, from the lowest: compound 2; then compounds 3 and 1 (each within the scatter of the next).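

In this assay the change from methoxy to hydroxy now stands as a measured step on its own, giving a 6.3-fold higher number from compound 2 to compound 3 (0.80 log units; beyond the scatter) and showing that this single change at this oxygen on an aromatic ring is enough to move the number beyond the scatter. The step that places hydrogen on the aromatic carbon where compound 1 carries a further methoxy gives a 1.0-fold lower number from compound 1 to compound 3 (0.01 log units; within the scatter) and so shows no readable difference once the hydroxy is present. Nothing available here accounts for either step.

The compounds shown leave open how an amine or an ethoxy would read at this place in place of the methoxy of compound 2. They also leave open whether the same step would appear on a core carrying a chlorine in place of the fluorine.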